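Outer ring change from compound 3 to compound 4

The source may report more compounds than this note shows. Statements on the series, on what has been measured and on what is new or still open speak of the compounds shown alone.

Three compounds of the series have numbers in an assay on cells for agonist activity at probable G-protein coupled receptor 34 (Mus musculus), with a stated time of 1 h; a lower number here means a smaller maximal response, a higher number a larger maximal response. Compound 1 `N[C@@H](COP(=O)(O)OCCCOC(=O)CCc1ccccc1OCc1cccc(Oc2ccccc2)c1)C(=O)O` gives 19.4% in this assay. Compound 2 `Cc1ccccc1Oc1cccc(COc2ccccc2CCC(=O)OCCCOP(=O)(O)OC[C@H](N)C(=O)O)c1` gives 20.3%, and compound 3 `N[C@@H](COP(=O)(O)OCCCOC(=O)CCc1ccccc1OCc1cccc(Oc2ccccc2Cl)c1)C(=O)O` gives 19.8%. Compound 3 sits alongside the other two: the steps of a number 0.4 percentage points higher from compound 1 to compound 3 (within the scatter) and a number 0.5 percentage points lower from compound 2 to compound 3 (within the scatter) both fall inside the usual scatter, as does a number 0.9 percentage points higher from compound 1 to compound 2 (within the scatter), so the three numbers cannot be told apart.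

Compound 4 `N[C@@H](COP(=O)(O)OCCCOC(=O)CCc1ccccc1OCc1cccc(Oc2ccc(Br)cc2)c1)C(=O)O` has not yet been measured. Its change from compound 3 is 4-bromophenyl in place of 2-chlorophenyl on an oxygen on an aromatic ring. The measured steps that bear on this are those on the same ring: a number 0.4 percentage points higher from compound 1 to compound 3 (within the scatter) and a number 0.9 percentage points higher from compound 1 to compound 2 (within the scatter), each a halogen or methyl placed on that ring, and each without effect beyond the scatter. On this basis no step beyond the scatter is expected for compound 4 in this assay, and the estimated step is no change at the digits printed from compound 3 to compound 4 (within the scatter). Compound 4 is therefore estimated at 19.8%, within a range from 14% to 26%.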

Compound 4, largest response reached (Emax), in percent of the reference or control that the assay uses: 17.7%
Compound 4: middle estimate off by 2.1 percentage points, on the high side; the range from low to high includes it.
By their numbers in this assay, from the lowest: compounds 4, 1, 3 and 2 (each within the scatter of the next).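

In this assay the outer ring on an oxygen on an aromatic ring now carries 4-bromophenyl, and both a number 2.1 percentage points lower from compound 3 to compound 4 (within the scatter) and a number 2.6 percentage points lower from compound 2 to compound 4 (within the scatter) stay inside the usual scatter of 2-chlorophenyl and 2-methylphenyl. With bromo in place of hydrogen, a number 1.7 percentage points lower from compound 1 to compound 4 (within the scatter) and the unsubstituted ring also cannot be told apart, so neither the halogen nor its place on this ring separates the maximal responses of these compounds. No measurement at hand explains these numbers.

Because the halogen and its place change together from compound 3 to compound 4, their separate contributions stay unresolved, and 2-bromophenyl or 4-chlorophenyl would divide them. From the compounds shown here alone, whether an amine or a carboxylic acid on this ring would move the maximal response beyond the scatter also remains open.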